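The source may hold more compounds than are shown below. What is called first, only, known or untested is meant among the compounds shown, and "the series" means these compounds.

Measured so far in an ADME assay on microsomes from liver (Rattus norvegicus) for metabolic stability; a higher number here means faster removal of the compound, a lower number slower removal:
- compound 1 `N#Cc1ccccc1Oc1ccc([C@H]2CC[C@@H](C(N)=O)N2)cc1`: 1.8 mL.min-1.g-1
- compound 2 `N#Cc1ccccc1COc1ccc([C@H]2CC[C@@H](C(N)=O)N2)cc1`: 1.4 mL.min-1.g-1

Compound 2 at 1.4 mL.min-1.g-1 lies within the usual scatter of compound 1 at 1.8 mL.min-1.g-1, so the two numbers set a single level for the series and give no order.

The next compound is compound 3 `NC(=O)[C@@H]1CC[C@H](c2ccc(OCc3ccc(F)cc3)cc2)N1`, which has not yet been measured. Its difference from compound 2 is 4-fluorophenyl in place of 2-cyanophenyl on a saturated chain carbon bound to an oxygen on an aromatic ring. The shared core stays unchanged.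

Among the measured compounds shown here, no pair of measured compounds differs in one place only, so the series offers no direct guide to the size of this exchange in this assay. The working expectation is a small rise in clearance, near the edge of the scatter rather than clearly past it. The estimated change is a 1.9-fold higher number from compound 2 to compound 3 (0.27 log units; within the scatter) on this expectation. Compound 3 is estimated at 2.6 mL.min-1.g-1 with an expected range from 1.2 mL.min-1.g-1 to 6 mL.min-1.g-1 for now.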

Compound 3, intrinsic clearance in microsomes: 1.8 mL.min-1.g-1
The estimate for compound 3 lay 1.4-fold (0.16 log units) above the measured number; the range from low to high includes it.
By their numbers in this assay, from the lowest: compounds 2, 1 and 3 (each within the scatter of the next).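

In this assay, among the compounds shown here, the exchange of 2-cyanophenyl for 4-fluorophenyl on a saturated chain carbon bound to an oxygen on an aromatic ring gives a 1.3-fold higher number from compound 2 to compound 3 (0.11 log units; within the scatter) as the first step that differs in one place only. At this place, then, the read-out does not separate the two groups: the nitrile can go and a fluorine can enter with the number staying inside the scatter, and compound 3 joins compounds 1 and 2 at the single level the series has held so far. No supporting data bear on this result, and the flat step stands as an observation only.

The compounds shown carry only these two substituted phenyl groups at this place, so the step says nothing about how far the level would hold with a quite different group there, such as a basic amine, a carboxylic acid or a longer alkyl chain. As far as these compounds go, whether any exchange at this place can move the number clearly past the scatter, in either direction, remains open for the series.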